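A smaller ring on the amide nitrogen of compound 1

This account rests on a few compounds, and the source may have more. Where it says the series, first, only, none or still open, it means among the compounds named here.

Going by the values given here, compound 1 `CCC(C)C(NC(=O)n1nnc2ccccc21)C(=O)NC1CCCCC1` is the only member of this small set with a numerical result. In a functional assay on MOLT-4 cells (Homo sapiens) for inhibition (a lower number here means a stronger inhibitor, a higher number a weaker inhibitor), compound 1 gives 98000 nM. Compound 2 `O=C1NC(c2ccccc2)C(=O)N1Cc1ccccc1` reaches only a limit of the assay, reported in this assay as > 200000 nM. Compound 3 `O=C1NC(c2ccccc2)C(=O)N1C1CCCC1` likewise reaches only a limit of the assay, reported in this assay as > 200000 nM. Among the compounds with values here, compound 1 thus stands as the sole measured number, the other two values sitting at the limit of > 200000 nM in this assay, at which 2 of the 3 values shown sit.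

Within the data shown here, no step between two measured compounds can be drawn, since compounds 1, 2 and 3 share no single-point change with one another.

Compound 4 `CCC(C)C(NC(=O)n1nnc2ccccc21)C(=O)NC1CCCC1` is the unmeasured partner of compound 1. The change is cyclopentyl in place of cyclohexyl on an amide-type nitrogen, the same difference read one bond further out as cyclohexylamino to cyclopentylamino. Among the measured compounds shown here, with no measured step to draw on, the expected change in this assay is small, none beyond the usual scatter, perhaps a slight drift toward weaker inhibition: the step expected is a 1.2-fold higher number from compound 1 to compound 4 (0.09 log units; within the scatter). Compound 4 is therefore estimated at 120000 nM in this assay, within a range from 50000 nM to 300000 nM, with a fair chance that only a limit is reported.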

Compound 4, half-maximal inhibitory concentration: 94000 nM
The estimate for compound 4 lay 1.3-fold (0.11 log units) above the measured number; measured number inside the range.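

In this assay, going by these compounds alone, cyclopentyl in place of cyclohexyl on the amide-type nitrogen gives a 1.0-fold lower number from compound 1 to compound 4 (0.02 log units; within the scatter), the only step in this set that can be read. Within the data shown here, it shows what the earlier compounds could not: at this position, going from the six-membered ring to the five-membered ring, with one carbon fewer, leaves the result within the scatter, so these two rings cannot be told apart in this assay. Compound 4 also gives a number rather than a limit, which means that the core of compound 1 now has two numerical results, and compound 2 and compound 3 stay at a limit of the assay: the limit of > 200000 nM in this assay, at which 2 of the 4 values shown sit.

The compounds shown leave open whether a group of a different kind on this nitrogen, such as a phenyl ring, a tert-butyl group or a cyclohexyl ring carrying an amine, would move the number beyond the scatter. They also leave open whether a change elsewhere on the core of compound 1 would give a much lower number than either ring does here.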